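The compounds below may be only part of what the source reports. "The series", "measured", "known", "first", "only" and "open" are said of these compounds alone.

Series notes. Compound 1 `C=C[C@@](C)(/C=C/c1ccc(O)cc1)CC/C=C(\C)C=O` and compound 2 `C=C[C@@](C)(/C=C/c1ccc(O)c(/C=C/C(=O)c2ccccc2)c1)CCC=C(C)C` have both been run in a functional assay on SEM cells (Homo sapiens) for cytotoxicity, with a stated time of 72 h; on this read-out higher numbers stand for an effect only at larger amounts of compound and lower numbers for an effect already at smaller amounts. For compound 1 the result is a limit of the assay rather than a number, > 36600 nM. In this assay compound 2 gives 8000 nM. Within the data shown here, compound 2 thus holds the only number so far in this assay. The remaining entry is the limit of > 36600 nM in this assay, at which 1 of the 2 values shown sits. Among the measured compounds shown here, since no two measured compounds differ in a single place, no measured step exists, and any expectation for the next compound must rest on the structural change alone.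

The next compound, compound 3 `C=C[C@@](C)(/C=C/c1ccc(O)c(/C=C/C=C/c2ccccc2)c1)CCC=C(C)C`, differs from compound 2 in one place: 2-phenylethenyl in place of benzoyl on a double-bonded chain carbon bound to a double-bonded chain carbon. The benzoyl carbonyl is replaced by a further chain double bond, and one hydrogen-bond acceptor is given up while size and ring count are unchanged. Expected in this assay: a 1.4-fold higher number from compound 2 to compound 3 (0.14 log units; within the scatter), a shift no larger than the usual scatter, if anything toward an effect only at larger amounts. On this basis compound 3 is estimated at 11000 nM in this assay, with a likely range from 3500 nM to 35000 nM.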

Compound 3, half-maximal effective concentration: > 15000 nM
Compound 3: no number, only a limit; the forecaster's own chance of this, stated with the estimate: 20%; middle value at least 1.3-fold (0.13 log units) from the limit.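

In this assay compound 3 gives > 15000 nM, a limit of the assay and not a number. Among these compounds, this is the first step that can be read: 2-phenylethenyl in place of benzoyl, on a double-bonded chain carbon bound to a double-bonded chain carbon, gives an at least 1.8-fold higher number from compound 2 to compound 3 (0.27 log units; that floor lies within the scatter), so the step shows no loss beyond the scatter, yet only the benzoyl compound holds a number at this place. The true size of the step stays unknown because compound 3 ends in a limit of the assay: the limit of > 15000 nM in this assay, at which 1 of the 3 values shown sits.

The compounds shown leave open whether the carbonyl or the aromatic ring of benzoyl matters more at this place, a question that acetyl, which keeps the carbonyl without the ring, would address. They also leave open what an amine or a carboxylic acid on the aromatic ring of benzoyl would do to the number in this assay.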